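This account rests on a few compounds, and the source may have more. Where it says the series, first, only, none or still open, it means among the compounds named here.

Compound 1 `Fc1ccc(C(SCCNC2CCN(Cc3ccc(Cl)cc3)CC2)c2ccc(F)cc2)cc1`: 45.5 nM
Compound 2 `O=C(c1ccccc1)N1CCC(NCCSC(c2ccc(F)cc2)c2ccc(F)cc2)CC1`: 2.03 nM
Compound 3 `O=C(c1cc2ccccc2[nH]1)N1CCC(NCCSC(c2ccc(F)cc2)c2ccc(F)cc2)CC1`: 1130 nM

All three were tested in an assay on membranes from Cortex for displacement of a labelled ligand from Sigma non-opioid intracellular receptor 1 (Cavia porcellus), read by scintillation counting, with a stated time of 120 min; a lower number here means a stronger inhibitor, a higher number a weaker inhibitor. Compound 3 stands highest of the three numbers, as the steps show: a 25-fold higher number from compound 1 to compound 3 (1.40 log units; beyond the scatter) and a 560-fold higher number from compound 2 to compound 3 (2.75 log units; beyond the scatter). Compound 4 `Fc1ccc(C(SCCNC2CCN(CC3CC3)CC2)c2ccc(F)cc2)cc1` differs from compound 3 in one place: cyclopropylmethyl in place of (1H-indol-2-yl)carbonyl on an amine nitrogen in a ring. The step that bears most on this change is a 25-fold higher number from compound 1 to compound 3 (1.40 log units; beyond the scatter), which runs the other way: a 4-chlorobenzyl group on that ring nitrogen went with the lower number in compound 1, and the carbonyl-bearing group with the higher one in compound 3. Compound 4 again carries a group joined through a methylene rather than a carbonyl, so a large step toward a lower number is expected, roughly undoing that one, though cyclopropylmethyl is not 4-chlorobenzyl and compound 4 need not match compound 1. Compound 4 is therefore expected to give about 50 nM, between 12 nM and 200 nM, an expected step of a 23-fold lower number from compound 3 to compound 4 (1.35 log units; beyond the scatter).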

Compound 4, inhibition constant: 269 nM
Compound 4: the middle estimate sits 5.4-fold (0.73 log units) below what was measured; measured number above the stated range.
By their numbers in this assay, from the lowest: compound 2; then compound 1; then compound 4; then compound 3.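

Replacing (1H-indol-2-yl)carbonyl with cyclopropylmethyl on the ring nitrogen gives only a 4.2-fold lower number from compound 3 to compound 4 (0.62 log units; beyond the scatter) and so losing the carbonyl does not by itself bring the number down far. Among groups joined through a methylene, the size of the end group also counts: cyclopropyl in place of 4-chlorophenyl gives a 5.9-fold higher number from compound 1 to compound 4 (0.77 log units; beyond the scatter) and cyclopropylmethyl in place of benzoyl gives a 130-fold higher number from compound 2 to compound 4 (2.12 log units; beyond the scatter) in a series where the benzoyl compound remains lowest. No measurement here explains these differences. Where a plain benzyl or an acetyl group on that ring nitrogen would fall remains open.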